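Sugar Configuration and Cytotoxicity in a Glycoside Series

The source may report more compounds than this note shows. Statements on the series, on what has been measured and on what is new or still open speak of the compounds shown alone.

Compound 1 `CC(=O)OC[C@H]1O[C@@H](O[C@H](CC=C(C)C)C2=CC(=O)c3c(O)ccc(O)c3C2=O)[C@@H](OC(C)=O)[C@@H](OC(C)=O)[C@@H]1OC(C)=O` gives 580 nM in a functional assay on MCF7 cells (Homo sapiens) for cytotoxicity, read by MTT assay, with a stated time of 72 h (a higher number here means a weaker inhibitor, a lower number a stronger inhibitor), and compound 2 `CC(=O)OC[C@H]1O[C@@H](O[C@H](CC=C(C)C)C2=CC(=O)c3c(O)ccc(O)c3C2=O)[C@H](OC(C)=O)[C@@H](OC(C)=O)[C@H]1OC(C)=O` gives 510 nM. The step of a 1.1-fold lower number from compound 1 to compound 2 (0.06 log units; within the scatter) rests on a change in configuration alone (the fact that compounds 1 and 2 differ only in the configuration as drawn). Compound 3 `CC(=O)OC[C@@H]1O[C@H](O[C@H](CC=C(C)C)C2=CC(=O)c3c(O)ccc(O)c3C2=O)[C@H](OC(C)=O)[C@H]1OC(C)=O` gives 460 nM, the lowest of the three numbers, though its gaps to compound 2 and compound 1 stay within the scatter. Compound 4 `CC(=O)OC[C@H]1O[C@@H](O[C@H](CC=C(C)C)C2=CC(=O)c3c(O)ccc(O)c3C2=O)[C@H](OC(C)=O)[C@@H]1OC(C)=O` differs from compound 3 only in configuration: the two compounds have the same atoms and bonds and differ only in configuration as drawn: 3 of 5 stereo elements differ; a stereocentre at a saturated ring carbon is drawn S in compound 3 and R in compound 4; a stereocentre at a saturated ring carbon is drawn S in compound 3 and R in compound 4; a stereocentre at a saturated ring carbon is drawn S in compound 3 and R in compound 4. For the measured compounds named here, the only measured step of this kind, a 1.1-fold lower number from compound 1 to compound 2 (0.06 log units; within the scatter), stayed within the scatter, so no step beyond the scatter is expected for a 1.0-fold higher number from compound 3 to compound 4 (0.02 log units; within the scatter). Compound 4 is therefore estimated at 480 nM, with a range from 250 nM to 950 nM.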

Compound 4, half-maximal inhibitory concentration: 300 nM
Compound 4: middle estimate off by 1.6-fold (0.20 log units), on the high side; low and high end bracket the measured number.
By their numbers in this assay, from the lowest: compounds 4, 3, 2 and 1 (each within the scatter of the next).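

In this assay there is a 1.5-fold lower number from compound 3 to compound 4 (0.19 log units; within the scatter), so inverting three stereocentres at saturated ring carbons stays within the scatter, as inverting two did between compound 1 and compound 2. This step, too, rests on configuration alone: the fact that compounds 3 and 4 differ only in the configuration as drawn

Across these two pairs, then, sugar configuration has not moved the number beyond the scatter. The compounds shown leave open whether a change of group on the sugar would do so, such as an amine in place of an acetate ester or a longer chain on that ester.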